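The source may report more compounds than this note shows. Statements on the series, on what has been measured and on what is new or still open speak of the compounds shown alone.

Measured so far in an assay on cerebellum for displacement of a labelled ligand from histamine H1 receptor (Cavia porcellus), read by scintillation counting, with a stated time of 60 min; a higher number here means a weaker inhibitor, a lower number a stronger inhibitor:

Compound 1 `CN1CCc2ccc(OCCCN3CCCCC3)cc2C1=O`: compound 1 gives 23 nM.
Compound 2 `CC1CCN(CCCOc2ccc3c(c2)C(=O)N(C)CC3)CC1`: compound 2 gives 32 nM.
Compound 3 `CC1CCCCN1CCCOc1ccc2c(c1)C(=O)N(C)CC2`: compound 3 gives 165 nM.

Compound 3 stands at the highest number of the three, hence the weakest inhibitor of this set; its nearest neighbour is compound 2, with a 5.2-fold higher number from compound 2 to compound 3 (0.71 log units; beyond the scatter), and the larger gap is a 7.2-fold higher number from compound 1 to compound 3 (0.86 log units; beyond the scatter). Compounds 1 and 2 differ by a 1.4-fold higher number from compound 1 to compound 2 (0.14 log units; within the scatter), so the 4-methylpiperidin-1-yl and the unsubstituted piperidin-1-yl are not separated here, while the 2-methylpiperidin-1-yl clearly is.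

Compound 4 `CN1CCc2ccc(OCCCN3CCC(O)CC3)cc2C1=O` is not yet measured. The change from compound 3 is 4-hydroxypiperidin-1-yl in place of 2-methylpiperidin-1-yl on a saturated chain carbon, three bonds along the chain from an oxygen on an aromatic ring. Among the measured compounds shown here, the steps that bear on it are those that remove or move the methyl of the 2-methylpiperidin-1-yl: going back from compound 3 to compound 1 or to compound 2 lowers the number by a modest amount in each case. For the measured compounds named here, a hydroxyl on the ring has no precedent in this set, so only the methyl removal can be weighed. The expectation in this assay is therefore a modest fall in number, about a 5.5-fold lower number from compound 3 to compound 4 (0.74 log units; beyond the scatter), toward the level of compounds 1 and 2. Compound 4 is estimated at 30 nM, with a range of 12 nM to 90 nM.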

Compound 4, inhibition constant: 35 nM
Beside the measured number, compound 4's estimate is 1.2-fold (0.07 log units) below it; the range from low to high includes it.
By their numbers in this assay, from the lowest: compounds 1, 2 and 4 (each within the scatter of the next); then compound 3.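

In this assay the 4-hydroxypiperidin-1-yl, on a saturated chain carbon, three bonds along the chain from an oxygen on an aromatic ring, stands clear of the 2-methylpiperidin-1-yl with a 4.7-fold lower number from compound 3 to compound 4 (0.67 log units; beyond the scatter) and so shows that this place can carry a ring substituent containing oxygen as well as the methyl groups seen earlier. Against the other two compounds, hydroxy in place of methyl gives a 1.1-fold higher number from compound 2 to compound 4 (0.04 log units; within the scatter) and hydroxy in place of hydrogen gives a 1.5-fold higher number from compound 1 to compound 4 (0.18 log units; within the scatter), so the unsubstituted piperidin-1-yl, the 4-methylpiperidin-1-yl and the 4-hydroxypiperidin-1-yl are not separated here, and among the compounds shown only the 2-methylpiperidin-1-yl stands apart. No measurement on these compounds offers an explanation for this result.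

Open still is whether the same holds for an amine or a carboxylic acid on that ring carbon, or for a 3-hydroxypiperidin-1-yl, where the hydroxyl sits elsewhere on the ring. Also open is whether the 4-hydroxypiperidin-1-yl keeps this level on a longer chain, since every compound shown has the same chain length.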